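Expecting compound 3 from a methyl-to-fluoro exchange

The source may hold more compounds than are shown below. What is called first, only, known or untested is meant among the compounds shown, and "the series" means these compounds.

Of the compounds shown here, two sharing one core have been tested in a functional assay on the whole organism (strain albino) for inhibition, with Rattus norvegicus as the target, read by paw edema, with stated times of 1 h and 2 h, at a dose of 200 mg/kg by the oral route; a higher number here means more inhibition at the dose given (going by the name of the read-out), a lower number less inhibition. Compound 1, `O=c1oc2ccccc2cc1C1=NN(c2ccccc2)[C@@H](c2ccc(Cl)cc2)C1`, carries a chloro group on an aromatic carbon, and in this assay compound 1 gives 39.2%. Compound 2, `Cc1ccc([C@H]2CC(c3cc4ccccc4oc3=O)=NN2c2ccccc2)cc1`, differs by a methyl in place of chloro on an aromatic carbon, and in this assay compound 2 gives 30.1%. Among the compounds with values here, the only step between measured compounds, a number 9.1 percentage points lower from compound 1 to compound 2 (within the scatter), lies within the scatter. Compound 2 thus stands at the lower of the two numbers, but that step being within the scatter, the two values cannot be told apart.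

Compound 3, `O=c1oc2ccccc2cc1C1=NN(c2ccccc2)[C@@H](c2ccc(F)cc2)C1`, has not yet been measured. It differs from compound 2 as follows: fluoro in place of methyl on an aromatic carbon. Within the data shown here, the one measured step, a number 9.1 percentage points lower from compound 1 to compound 2 (within the scatter), also exchanges the group on the same aromatic carbon. That step stayed within the scatter. Nothing measured here suggests a larger movement for the exchange of methyl for fluoro. The step of a number 5.9 percentage points higher from compound 2 to compound 3 (within the scatter) is therefore expected to remain within the scatter. In this assay compound 3 is expected to give 36%, with a range from 26% to 46%.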

Compound 3, a percentage reported as inhibition, in the whole organism at one dose (the size of the read-out at that dose, not a potency): 44.9%
Estimate against measurement, compound 3: 8.9 percentage points below; low and high end bracket the measured number.
By their numbers in this assay, from the lowest: compounds 2, 1 and 3 (each within the scatter of the next, the first and the last beyond it).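

In this assay, within the data shown here, the exchange of 4-methylphenyl to 4-fluorophenyl gives a number 14.8 percentage points higher from compound 2 to compound 3 (beyond the scatter), the first step at this aromatic carbon that clears the usual scatter and so the first sign that the group para to a large group can shift the inhibition of paw edema at this dose. The exchange of one halogen for the other does not separate the compounds, since a number 5.7 percentage points higher from compound 1 to compound 3 (within the scatter) stays within the scatter, as does a number 9.1 percentage points lower from compound 1 to compound 2 (within the scatter), so chloro sits within the scatter of both other groups and only the methyl and fluoro compounds can be told apart. Nothing available here accounts for the gap between the methyl and fluoro compounds.

The compounds shown leave open how this position would respond to a quite different group, such as a methoxy, an amine or a carboxylic acid. They also leave open whether the separation between methyl and fluoro would persist at other doses, or whether the same exchange elsewhere on the shared core would produce a step of similar size.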